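The source may hold more compounds than are shown below. What is called first, only, known or untested is meant among the compounds shown, and "the series" means these compounds.

Measured in a functional assay on SF-295 cells (Homo sapiens) for cytotoxicity, read by sulforhodamine B assay, with a stated time of 48 h; on this read-out higher numbers stand for weaker inhibition of growth and lower numbers for stronger inhibition of growth:
Compound 1, `ClCc1cccc(Cn2cnc3ncnc(Cl)c32)c1`, gives 6300 nM.
Compound 2, `ClCc1cccc(Cn2cnc3c(Cl)ncnc32)c1`, gives 3230 nM.

Compound 1 stands with the higher of the two numbers, though its gap to compound 2 lies within the scatter, so no order between them can be claimed. Compound 3, `ClCc1cccc(Cn2cnc3nc(Cl)nc(Cl)c32)c1`, differs from compound 1 by chloro in place of hydrogen on an aromatic carbon. Within the data shown here, no step between measured compounds shows the effect of such a change in this assay, so a small step, if any, is expected. Compound 3 is accordingly expected to give about 4500 nM, between 1500 nM and 13000 nM, a step of a 1.4-fold lower number from compound 1 to compound 3 (0.15 log units; within the scatter).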

Compound 3, concentration for 50% growth inhibition: 1860 nM
Compound 3: middle estimate off by 2.4-fold (0.38 log units), on the high side; the range from low to high includes it.
By their numbers in this assay, from the lowest: compounds 3, 2 and 1 (each within the scatter of the next, the first and the last beyond it).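

In this assay, chloro in place of hydrogen on the aromatic carbon between two ring nitrogen atoms gives a 3.4-fold lower number from compound 1 to compound 3 (0.53 log units; beyond the scatter), a modest step beyond the scatter. Among these compounds, this is the first sign that a change at this position can shift the read-out in the core of compound 1. Nothing at hand accounts for the step.

As far as these compounds go, whether an amine or a methoxy group on the same carbon would shift the number in the same direction remains open. So does whether the step is specific to chloro.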